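This account rests on a few compounds, and the source may have more. Where it says the series, first, only, none or still open, it means among the compounds named here.

Measured compounds in a functional assay on A549 cells (Homo sapiens) for antiproliferative activity, read by XTT assay, with a stated time of 72 h; on this read-out lower numbers stand for stronger inhibition and higher numbers for weaker inhibition:
compound 1 `COc1ccc(-c2cc3ccccc3nc2/C=C/C(=O)c2ccc(F)cc2)cc1`: 8320 nM
compound 2 `COc1ccc(-c2cc3ccccc3nc2/C=C/C(=O)c2ccc(O)cc2)cc1`: 7440 nM
compound 3 `COc1ccc(-c2cc3ccccc3nc2/C=C/C(=O)c2cccs2)cc1`: 920 nM

Compound 2 gives the second highest of the three numbers; against compound 1 it differs only within the scatter (a 1.1-fold lower number from compound 1 to compound 2 (0.05 log units; within the scatter)), while compound 3 sits well apart from it (an 8.1-fold lower number from compound 2 to compound 3 (0.91 log units; beyond the scatter)).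

Compound 4 `COc1ccc(-c2cc3ccccc3nc2/C=C/C(=O)c2c[nH]c3ccccc23)cc1` is not yet measured. The change from compound 2 is 1H-indol-3-yl in place of 4-hydroxyphenyl on a carbonyl carbon.

Among the compounds with values here, the steps that bear on this change are the two that also replace the group on the carbonyl carbon: a 9.0-fold lower number from compound 1 to compound 3 (0.96 log units; beyond the scatter) and an 8.1-fold lower number from compound 2 to compound 3 (0.91 log units; beyond the scatter). Both are modest and point toward lower numbers when a heteroaromatic group stands in place of a substituted phenyl on that carbon. The entering group in compound 4 is not the same as that in compound 3, so the size is uncertain, but a step toward a lower number beyond the scatter is expected for compound 4, of about a 2.1-fold lower number from compound 2 to compound 4 (0.33 log units; beyond the scatter).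

Compound 4 is therefore estimated at 3500 nM in this assay, with a range from 900 nM to 13000 nM.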

Compound 4, half-maximal inhibitory concentration: > 10000 nM
Compound 4 gave a limit, no number; the forecaster's own chance of this, stated with the estimate: 5%; at least 2.8-fold (0.45 log units) between middle value and limit.
By their numbers in this assay, from the lowest: compound 3; then compounds 2 and 1 (each within the scatter of the next). At a limit, above all of these: compound 4.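

In this assay compound 4 gives a limit, not a number: the limit of > 10000 nM in this assay, at which 1 of the 4 values shown sits. The lower number found with thiophen-2-yl on the carbonyl carbon does not carry over to 1H-indol-3-yl, with an at least 10-fold higher number from compound 3 to compound 4 (1.03 log units; beyond the scatter), so a five-membered aromatic ring with a hetero atom on that carbon does not by itself give the lower number. Against the substituted phenyl groups the floors, an at least 1.3-fold higher number from compound 2 to compound 4 (0.12 log units; that floor lies within the scatter) and an at least 1.2-fold higher number from compound 1 to compound 4 (0.07 log units; that floor lies within the scatter), lie within the scatter, so they show no gain from 1H-indol-3-yl but give no size for the change.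

Going by these compounds, it remains open whether the lower number of compound 3 is particular to thiophen-2-yl or extends to furan-2-yl or pyridin-3-yl on the carbonyl carbon. Also open, on these data alone, is how far the true number of compound 4 lies from those of compound 1 and compound 2.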